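A few compounds are considered here, and "the series" means these few. Any claim that something is new, unique, unknown or untested is made for them only; others in the source may bear on it.

- compound 1 (`Oc1cccc2c1nc(-c1c(F)cccc1F)n2Cc1c(F)cccc1F`): > 100 uM
- compound 2 (`N#Cc1cccc2c1nc(-c1c(F)cccc1F)n2Cc1c(F)cccc1F`): 26.7 uM

In a toxicity assay on CCRF-CEM cells (Homo sapiens) for cytotoxicity (a higher number here means that more compound is tolerated, a lower number that less compound is tolerated), the entry for compound 1 is a limit, > 100 uM. Among the measured compounds shown here, compound 2 has the only actual number, 26.7 uM. Compound 3 (`NC(=O)c1cccc2c1nc(-c1c(F)cccc1F)n2Cc1c(F)cccc1F`) differs from compound 2 by carbamoyl in place of cyano on an aromatic carbon. For the measured compounds named here, the one measured step at this aromatic carbon is an at least 3.7-fold lower number from compound 1 to compound 2 (0.57 log units; beyond the scatter), beyond the scatter and resting on (the limit of > 100 uM in this assay, at which 1 of the 2 values shown sits). It is a loose guide, since a different group enters here. A modest rise is expected in this assay, estimated as a 2.1-fold higher number from compound 2 to compound 3 (0.31 log units; beyond the scatter). For compound 3 the estimate is 55 uM, with an expected range of 20 uM to 100 uM.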

Compound 3, half-maximal toxic concentration: > 100 uM
Compound 3 ended at the assay's limit (the forecaster's own chance of this, stated with the estimate: 35%); at least 1.8-fold (0.25 log units) between middle value and limit.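

In this assay carbamoyl in place of cyano on this aromatic carbon gives an at least 3.7-fold higher number from compound 2 to compound 3 (0.57 log units; beyond the scatter) and so takes the number back up to the limit. Of the three groups shown here, only the cyano group of compound 2 gives a number short of that limit. The size of this rise is only a minimum: the limit of > 100 uM in this assay, at which 2 of the 3 values shown sit.

The step between the two compounds at the limit cannot be read, so hydroxy and carbamoyl stay unordered. Going by these compounds, whether an amine, a carboxylic acid or a methyl ester at this carbon would also reach the limit stays open.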